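This account rests on a few compounds, and the source may have more. Where it says the series, first, only, none or still open, it means among the compounds named here.

Three compounds built on one shared core have all been tested in a functional assay, read by spectrophotometry, with a stated time of 15 min, tested at 20 ug/mL; a higher number here means a stronger effect of the compound at the concentration tested, a lower number a weaker effect. Compound 1 `COC(=O)c1cc(-c2csc(N/N=C/c3cccs3)n2)ccc1OCc1ccccc1` gives 79.6%. Compound 2 `Fc1ccc(-c2csc(N/N=C/c3ccc(Cl)cc3Cl)n2)cc1` gives 88.4%. Compound 3 `Fc1ccc(-c2csc(N/N=C/c3cccs3)n2)cc1` gives 84.2%. The number for compound 2 is the highest of the three, but its gaps to compound 3 and to compound 1 both lie within the usual scatter of repeated measurements, so these three numbers do not set the compounds apart from one another.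

Compound 4 `COc1ccc(-c2csc(N/N=C/c3ccc(Cl)cc3Cl)n2)cc1` has not yet been measured. It differs from compound 2 in a single place: methoxy in place of fluoro on an aromatic carbon. Seen one bond further out, a 4-fluorophenyl becomes a 4-methoxyphenyl. Within the data shown here, no pair of measured compounds shows this same change, so there is no measured step to lean on, and a small swap of this kind is expected to give a step that stays within the scatter, if anything a slight decrease. On that basis compound 4 is expected to reach about 84%, with a range from 70% to 95%. The step of a number 4.4 percentage points lower from compound 2 to compound 4 (within the scatter) that this estimate means is expected to be small.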

Compound 4, a percentage reported as inhibition, at one concentration (the size of the read-out at that concentration, not a potency): 78.1%
The estimate for compound 4 lay 5.9 percentage points above the measured number; low and high end bracket the measured number.
By their numbers in this assay, from the lowest: compounds 4, 1, 3 and 2 (each within the scatter of the next, the first and the last beyond it).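

Among these compounds, this is the first change at this position, on an aromatic carbon para to a large group, whose effect can be told apart from the noise: in this assay, methoxy in place of fluoro gives a number 10.3 percentage points lower from compound 2 to compound 4 (beyond the scatter). The position is therefore not indifferent to what sits on it, since a 4-fluorophenyl and a 4-methoxyphenyl give different read-outs here, although the step is modest and rests on a single pair of compounds. Nothing measured here gives a reason for this step.

Among the compounds shown here, whether the same swap would lower the number on compound 3 remains open, as only one pair carries it. The compounds shown also leave open how an amine, a carboxylic acid or a longer alkoxy chain at this position would read.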